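Working notes: phenyl for ethyl on the carbonyl

The compounds below may be only part of what the source reports. "The series", "measured", "known", "first", "only" and "open" are said of these compounds alone.

Going by the values given here, the series so far holds three measured compounds and one yet to be measured, all tested in an assay on Sf9 cells for inhibition of mitogen-activated protein kinase kinase kinase 14 (Homo sapiens), read by ADP-Glo, with a stated time of 60 min; on this read-out lower numbers stand for stronger inhibition and higher numbers for weaker inhibition. Compound 1 `Cc1[nH]nc(N)c1-c1ccc2ccccc2c1` reaches only a limit of the assay, recorded as > 100000 nM. Compound 2 `Cc1[nH]nc(N)c1-c1cccc(C(F)(F)F)c1` likewise gives only a limit, > 100000 nM. Among the compounds with values here, compound 3 `CCC(=O)n1nc(C)c(-c2ccc(Cl)c(Cl)c2)c1N` is the single member with a number rather than a limit, at 27400 nM in this assay, so compound 3 stands alone as the only quantified point; the remaining two values sit at the limit of > 100000 nM in this assay, at which 2 of the 3 values shown sit.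

Compound 4 `Cc1nn(C(=O)c2ccccc2)c(N)c1-c1ccc(Cl)c(Cl)c1` differs from compound 3 in one place: phenyl in place of ethyl on a carbonyl carbon. Within the data shown here, no step between measured compounds is available to show what such a change does in this assay, so the expected size of the step rests on compound 3 alone. Among the measured compounds shown here, with compound 3 at 27400 nM as the only anchor and no comparable pair to lean on, a step of moderate size is expected, with a slight lean toward stronger inhibition but with the scatter of the assay wide enough that no direction is secure.

For compound 4 the estimate in this assay is 15000 nM, with a range from 3000 nM to 80000 nM. That estimate corresponds to an expected step of a 1.8-fold lower number from compound 3 to compound 4 (0.26 log units; within the scatter), and it remains possible that the assay returns only a limit for compound 4.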

Compound 4, half-maximal inhibitory concentration: 23000 nM
Beside the measured number, compound 4's estimate is 1.5-fold (0.19 log units) below it, and the stated range covers the measured number.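

Working notes, continued. In this assay, the carbonyl carbon whose other neighbour is an aromatic nitrogen now has its first readable step, with phenyl in place of ethyl giving a 1.2-fold lower number from compound 3 to compound 4 (0.08 log units; within the scatter). The assay cannot separate the two groups at this place, so a six-membered aromatic ring of carbon only is accepted there as well as ethyl, and compound 4 gives a number rather than a limit. Compound 1 and compound 2 remain limits of the assay, not numbers: the limit of > 100000 nM in this assay, at which 2 of the 4 values shown sit.

On these data alone, whether a methoxy group, an amine or a longer chain such as butyl on the same carbonyl carbon would also leave the value in place stays open, and one pair gives no trend for this position. Compound 1 and compound 2 each differ from compound 3 in more than one place, so the series shown does not isolate what the carbonyl group itself, or the dichlorophenyl part of compound 3 and compound 4, contributes to the read-out.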